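The source may hold more compounds than are shown below. What is called first, only, known or untested is meant among the compounds shown, and "the series" means these compounds.

Measured so far in a functional assay on MDA-MB-231 cells (Homo sapiens) for inhibition, read by WST assay, with a stated time of 48 h; a higher number here means a weaker inhibitor, a lower number a stronger inhibitor:
Compound 1 (`CC/C=C\C/C=C\C/C=C\C/C=C\C/C=C\C/C=C\CCC(=O)Oc1ccc(C(C)C)cc1C(C)C`) – 7300 nM
Compound 2 (`CC/C=C\C/C=C\C/C=C\C/C=C\C/C=C\C/C=C\CCC(=O)Oc1ccccc1C1CCCCC1`) – 8400 nM

Among the compounds with values here, on these two numbers, compound 1 cannot be told apart from its only measured neighbour: the one step in hand (a 1.2-fold higher number from compound 1 to compound 2 (0.06 log units; within the scatter)) lies within the scatter. Compound 3 (`CC/C=C\C/C=C\C/C=C\C/C=C\C/C=C\C/C=C\CCC(=O)Oc1c(C(C)C)cccc1C(C)C`) has not yet been measured. Its difference from compound 1 (2,6-diisopropylphenyl in place of 2,4-diisopropylphenyl on an oxygen next to a carbonyl group) is 2,6-diisopropylphenyl in place of 2,4-diisopropylphenyl on an oxygen next to a carbonyl group. The measured step bears on this. It changed the group at that same place, putting 2-cyclohexylphenyl in place of 2,4-diisopropylphenyl. Within the data shown here, no measured compound carries 2,6-diisopropylphenyl, so the evidence is thin. The expected change (a 1.1-fold higher number from compound 1 to compound 3 (0.04 log units; within the scatter)) stays within the scatter of this assay and has no expected direction. Compound 3 is expected at 8000 nM with 3500 nM to 18000 nM as its estimated range.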

Compound 3, half-maximal inhibitory concentration: 2900 nM
For compound 3 the middle estimate is 2.8-fold (0.44 log units) above the measured one, outside the stated range (below it).
By their numbers in this assay, from the lowest: compound 3; then compounds 1 and 2 (each within the scatter of the next).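

The earlier step had shown no readable change at the group on an oxygen next to a carbonyl group, but this result shows that this assay can respond to the group there. With the same atoms joined differently, 2,6-diisopropylphenyl in place of 2,4-diisopropylphenyl gives a 2.5-fold lower number from compound 1 to compound 3 (0.40 log units; beyond the scatter), and 2,6-diisopropylphenyl in place of 2-cyclohexylphenyl gives a 2.9-fold lower number from compound 2 to compound 3 (0.46 log units; beyond the scatter), both modest steps beyond the scatter. Nothing given here accounts for the difference between these groups.

The compounds shown leave open whether the 2,6-diisopropylphenyl result is particular to that group or extends to others at this place, such as 2,6-dimethylphenyl or 2,6-di-tert-butylphenyl. They also leave open how a 2,6-dicyclohexylphenyl group would compare with compound 3 on the same shared core.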